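The source may report more compounds than this note shows. Statements on the series, on what has been measured and on what is new or still open speak of the compounds shown alone.

Measured compounds:
- compound 1, `CC(C)Cc1ccc2c(NCCCNCc3ccco3)ccnc2c1`, 23 10^-6 cm/s in an ADME assay for permeability, using PAMPA, with a stated time of 30 min, at pH 7.4; on this read-out lower numbers stand for lower permeability and higher numbers for higher permeability
- compound 2, `CC(C)(C)c1ccc(Oc2ccc3c(NCCCNCc4ccco4)ccnc3c2)cc1`, 317 10^-6 cm/s in this assay
- compound 3, `CCC(CC)c1ccc2c(NCCCNCc3ccco3)ccnc2c1`, 23 10^-6 cm/s in this assay

Compound 3 stands level with compound 1 in this assay, the two together at the low end of the three numbers; the step of no change at the digits printed from compound 1 to compound 3 (within the scatter) lies within the scatter. Compound 2 sits far above compound 3, its value being a good deal higher than that of compound 3 in this assay.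

Compound 4 is `Clc1ccc(Oc2ccc3c(NCCCNCc4ccco4)ccnc3c2)cc1`. The change from compound 3 is 4-chlorophenoxy in place of pentan-3-yl on an aromatic carbon. Within the data shown here, no measured step bears directly on this change. Among the measured compounds shown here, the only measured step, no change at the digits printed from compound 1 to compound 3 (within the scatter), swaps one alkyl chain for another and shows nothing beyond the scatter. What does bear on it is the standing of compound 2, which carries a phenoxy group in the same place and gives 317 10^-6 cm/s in this assay, while compound 3 with its alkyl chain gives 23 10^-6 cm/s. On that basis the step of a 7.8-fold higher number from compound 3 to compound 4 (0.89 log units; beyond the scatter) is expected to be upward and well beyond the scatter. Compound 4 is therefore estimated at 180 10^-6 cm/s in this assay, with a range from 60 10^-6 cm/s to 400 10^-6 cm/s.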

Compound 4, apparent permeability: 317 10^-6 cm/s
For compound 4 the middle estimate is 1.8-fold (0.25 log units) below the measured one; measured number inside the range.
By their numbers in this assay, from the lowest: compounds 1 and 3 (each within the scatter of the next); then compounds 2 and 4 (each within the scatter of the next).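

In this assay, the number rises sharply when 4-chlorophenoxy takes the place of an alkyl group on this aromatic carbon, with a 14-fold higher number from compound 3 to compound 4 (1.14 log units; beyond the scatter) for the loss of pentan-3-yl and a 14-fold higher number from compound 1 to compound 4 (1.14 log units; beyond the scatter) for the loss of isobutyl. Compound 2 alone could not show whether its high number depended on its tert-butyl group, but chloro in that place gives no change at the digits printed from compound 2 to compound 4 (within the scatter). Across these four compounds, the two with a substituted phenoxy group stand level at the high end and the two with an alkyl chain stand level at the low end, and none of the four goes against that split.

The compounds shown leave open whether the high level would hold with a plain phenoxy group, with an amine or a carboxylic acid on the phenoxy ring, or with a benzyl group, which has a carbon where the phenoxy group has its oxygen. Nothing presented here gives a measured reason for the gap between the two pairs.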